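Lengthening the Alkyl Chain of an Inactive Dienamide

This account rests on a few compounds, and the source may have more. Where it says the series, first, only, none or still open, it means among the compounds named here.

Measured compounds:
Compound 1 `CCCCCCCCCCCCNC(=O)[C@@H](NC(=O)c1ccccc1)[C@@H](C)O` gives > 400000 nM in a functional assay on HepG2 cells (Homo sapiens) for cytotoxicity, read by MTT assay, with a stated time of 48 h; on this read-out higher numbers stand for weaker inhibition and lower numbers for stronger inhibition; this is a limit, not a number.
Compound 2 `CCCCCCCCCCCCNC(=O)[C@@H](NC(=O)c1ccco1)[C@@H](C)O` gives 147000 nM in this assay.
Compound 3 `C/C=C/C=C/C(=O)N[C@H](C(=O)NCCCCCCCCCCCC)[C@@H](C)O` gives > 400000 nM in this assay; this too is a limit, not a number.

Compound 3 therefore stands at the top of what this assay reports, where two of the three values sit (the limit of > 400000 nM in this assay, at which 2 of the 3 values shown sit). Of the three, only compound 2 yields a number, and the step of an at least 2.7-fold higher number from compound 2 to compound 3 (0.43 log units; beyond the scatter) shows that compound 3 sits at a weaker level than that.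

Compound 4 `C/C=C/C=C/C(=O)N[C@H](C(=O)NCCCCCCCCCCCCCCCCCC)[C@@H](C)O` differs from compound 3 by hexyl in place of hydrogen on a saturated chain carbon, ten or more bonds along the chain from an amide-type nitrogen. Among the compounds with values here, none of the measured steps concerns this part of the molecule: the steps of an at least 2.7-fold lower number from compound 1 to compound 2 (0.43 log units; beyond the scatter) and a step that the two limits leave unreadable from compound 1 to compound 3 and an at least 2.7-fold higher number from compound 2 to compound 3 (0.43 log units; beyond the scatter) all exchange the group on the carbonyl carbon and leave the chain untouched. So no measured step bears on the change, and nothing points to a move away from the limit in either direction.

Compound 3 is expected to pass into compound 4 with a step of a number no higher from compound 3 to compound 4 (the limit leaves the size open) in this assay, which is to say no readable change. Compound 4 is expected to give about 400000 nM, within 120000 nM and 1300000 nM, with a good chance that only a limit is reported again.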

Compound 4, half-maximal inhibitory concentration: 284000 nM
Compound 4: the middle estimate sits 1.4-fold (0.15 log units) above what was measured; the range from low to high includes it.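

The step shown here is the only one that touches the chain rather than the group on the carbonyl carbon: hexyl in place of hydrogen on a saturated chain carbon, ten or more bonds along the chain from an amide-type nitrogen, gives compound 4 a measurable number in this assay. Compound 3 gives > 400000 nM, which is a limit and not a number. The comparison therefore reads an at least 1.4-fold lower number from compound 3 to compound 4 (0.14 log units; that floor lies within the scatter), so the longer chain may have lowered the number by more than this floor, but the floor alone does not establish a real change.

On these data alone, the true size of this step stays open, since the values at the top of the read-out remain limits rather than numbers: the limit of > 400000 nM in this assay, at which 2 of the 4 values shown sit. Also open is whether a longer chain than that of compound 4, or an amine or a carboxylic acid on this chain, would move the number further, and whether hexyl in this place would have any comparable effect on compound 2, which already gives a number.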